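Side-chain swaps on the shared core

The source may report more compounds than this note shows. Statements on the series, on what has been measured and on what is new or still open speak of the compounds shown alone.

Compound 3 `CC1=C(N2CC2)C(=O)C(CCC(=O)N(C)C)=C(N2CC2)C1=O` gives 5.09 in a functional assay on L1210 cells (Mus musculus), with a stated time of 1 days (on this read-out lower numbers stand for lower potency and higher numbers for higher potency (the scale is a negative logarithm)), the second highest of the three numbers measured. Compound 1 `CC1=C(N2CC2)C(=O)C(Cc2ccccc2)=C(N2CC2)C1=O` gives 4.74 and compound 2 `CC1=C(N2CC2)C(=O)C(C(C)COC(N)=O)=C(N2CC2)C1=O` gives 5.93; the step of a number 0.35 log units higher from compound 1 to compound 3 (beyond the scatter) is modest, the step of a number 1.19 log units higher from compound 1 to compound 2 (beyond the scatter) is large, and the step of a number 0.84 log units lower from compound 2 to compound 3 (beyond the scatter) is modest. Compound 4 `CCC(OC)C1=C(N2CC2)C(=O)C(C)=C(N2CC2)C1=O` differs from compound 3 by 1-methoxypropyl in place of 2-(dimethylcarbamoyl)ethyl on a double-bonded ring carbon. The two side-chain exchanges already measured, a number 1.19 log units higher from compound 1 to compound 2 (beyond the scatter) and a number 0.84 log units lower from compound 2 to compound 3 (beyond the scatter), show that such exchanges move this assay by large or modest amounts in either direction, so the present change is unlikely to be neutral but its direction is uncertain. A small rise is expected, a number 0.21 log units higher from compound 3 to compound 4 (within the scatter), with a wide range. Compound 4 is estimated at 5.3, between 4.6 and 6.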

Compound 4, logarithm of the reciprocal of the active concentration, log(1/C): 5.26
Compound 4: the middle estimate sits 0.04 log units above what was measured; low and high end bracket the measured number.
By their numbers in this assay, from the lowest: compound 1; then compounds 3 and 4 (each within the scatter of the next); then compound 2.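

In this assay, for the compounds shown here, 1-methoxypropyl in place of 2-(dimethylcarbamoyl)ethyl (a number 0.17 log units higher from compound 3 to compound 4 (within the scatter)) is the first side-chain exchange here that does not separate two compounds, even though the amide is lost and the side chain is shorter by heavy-atom count. The same group stays apart from the other two side chains (a number 0.67 log units lower from compound 2 to compound 4 (beyond the scatter); a number 0.52 log units higher from compound 1 to compound 4 (beyond the scatter)). Nothing measured on these compounds accounts for these numbers. Open, on these data alone, is whether the methoxy oxygen or the branching of 1-methoxypropyl matters at this ring carbon. Also open, as far as these compounds go, is how a side chain carrying an amine or a carboxylic acid would read there.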